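Acetyl to ethylamidine on the pyridine core: compound 3

The source may hold more compounds than are shown below. What is called first, only, known or untested is meant among the compounds shown, and "the series" means these compounds.

Measured compounds:
- Compound 1 `C[C@H]1CN(c2ncc(C(=O)NCc3ccc(F)c(F)c3)cc2Cl)CCN1C1CCN(Cc2ccc(Cl)cc2)CC1`: 6 nM
- Compound 2 `CC(=O)c1cnc(N2CCN(C3CCN(Cc4ccc(Cl)cc4)CC3)[C@@H](C)C2)c(Cl)c1`: 520 nM

In a functional assay for antagonist activity at C-X-C chemokine receptor type 3 (Homo sapiens) (on this read-out lower numbers stand for stronger inhibition and higher numbers for weaker inhibition), compound 1 gives 6 nM and compound 2 gives 520 nM. Among the measured compounds shown here, compound 2 therefore stands at the highest number of the two measured; its only neighbour is compound 1, reached by an 87-fold higher number from compound 1 to compound 2 (1.94 log units; beyond the scatter), a step beyond the scatter.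

Compound 3 `CCNC(=N)c1cnc(N2CCN(C3CCN(Cc4ccc(Cl)cc4)CC3)[C@@H](C)C2)c(Cl)c1` is not yet measured. Relative to compound 2, the change is a group of 5 heavy atoms (3 carbon, 2 nitrogen; no ring) in place of a group of 3 heavy atoms (2 carbon, 1 oxygen; no ring), on an aromatic carbon. For the measured compounds named here, the one measured step that bears on this site, an 87-fold higher number from compound 1 to compound 2 (1.94 log units; beyond the scatter), shows that a large substituent on that carbonyl carbon gives a much lower number than the bare methyl ketone. The new group in compound 3 is larger than acetyl and carries hydrogen-bond donors, but it remains far smaller than the (3,4-difluorobenzyl)amino group of compound 1, so only part of that gain is expected to return.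

For compound 3 the step of a 2.6-fold lower number from compound 2 to compound 3 (0.41 log units; beyond the scatter) is expected in this assay. The estimate for compound 3 is 200 nM, with a range from 40 nM to 1500 nM.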

Compound 3, half-maximal inhibitory concentration: 83 nM
Compound 3: the middle estimate sits 2.4-fold (0.38 log units) above what was measured; measured number inside the range.
By their numbers in this assay, from the lowest: compound 1; then compound 3; then compound 2.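

In this assay, a 6.3-fold lower number from compound 2 to compound 3 (0.80 log units; beyond the scatter) shows that this aromatic carbon, two atoms from the ring nitrogen, can regain part of the lost activity without a carbonyl and without any ring in the substituent, using a short ethylamidine that brings in hydrogen-bond donors where acetyl has none. Even so, a 14-fold higher number from compound 1 to compound 3 (1.14 log units; beyond the scatter), so the small unbranched group does not reach the level of the amide carrying the 3,4-difluorobenzyl group, and the step from compound 3 to compound 1 adds size and an aromatic ring at once. No measurement in hand explains either step at this position.

Size, donor count and the loss of the carbonyl all change together in the step to compound 3, so the compounds shown cannot say which of them carries the gain; a simple ethyl amide on the same carbon would separate the amidine from the ethyl chain. Also open, from the compounds shown here alone, is whether the amidine and the 3,4-difluorobenzyl group add up, which a 3,4-difluorobenzyl amidine at this position would test directly.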